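The compounds below may be only part of what the source reports. "The series", "measured", "known", "first", "only" and "open" are said of these compounds alone.

Going by the values given here, in a functional assay on the whole organism (strain Sprague-Dawley) for inhibition, with Rattus norvegicus as the target, with a stated time of 10 min (on this read-out lower numbers stand for an effect already at smaller amounts and higher numbers for an effect only at larger amounts of compound), three compounds have numbers so far. Compound 3 (`CCCOc1ccccc1-c1ncc(C(=O)OCC)c(=O)[nH]1`) gives 5 mg/kg. Compound 2 (`CCOC(=O)c1cnc(-c2ccccc2Cl)[nH]c1=O`) stands level with it at 5 mg/kg, and the two share the highest number of the set. Compound 1 (`CC(C)Oc1ccccc1-c1ncc(C(=O)O)c(=O)[nH]1`) gives 0.8 mg/kg, a lower number beyond the scatter.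

Compound 4 (`CCOC(=O)c1cnc(-c2ccccc2OC(C)C)[nH]c1=O`) has the same atoms as compound 3, joined differently: isopropyl in place of propyl on an oxygen on an aromatic ring, with isopropyl in place of propyl on an oxygen on an aromatic ring. Among the compounds with values here, no measured step makes this exact change. The closest evidence is no change at the digits printed from compound 2 to compound 3 (within the scatter), where propoxy in place of chloro on an aromatic carbon left this assay within the scatter. Compound 1 also carries isopropyl on that oxygen, but it differs from compound 4 elsewhere, so compound 1 at 0.8 mg/kg gives only a weak pull towards lower numbers.

A small move towards a lower number is therefore expected, with no change beyond the scatter. The expected step is a 1.3-fold lower number from compound 3 to compound 4 (0.10 log units; within the scatter). For compound 4 the estimate is 4 mg/kg, with an expected range of 1.5 mg/kg to 10 mg/kg.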

Compound 4, dose for 50% inhibition: 2 mg/kg
Beside the measured number, compound 4's estimate is 2.0-fold (0.30 log units) above it; measured number inside the range.
By their numbers in this assay, from the lowest: compound 1; then compound 4; then compounds 2 and 3 (each within the scatter of the next).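

In this assay the step of a 2.5-fold lower number from compound 3 to compound 4 (0.40 log units; beyond the scatter) shows that on this oxygen it matters how the three carbons are joined, a difference that the earlier step of no change at the digits printed from compound 2 to compound 3 (within the scatter) could not reveal. Chloro and an ether at this place also come apart once the chain is isopropyl, with a 2.5-fold lower number from compound 2 to compound 4 (0.40 log units; beyond the scatter) as the reading for that exchange. Going by these compounds alone, with isopropoxy held constant, the step of a 2.5-fold higher number from compound 1 to compound 4 (0.40 log units; beyond the scatter) gives the first direct reading of the ethyl ester against the free carboxylic acid.

The compounds shown offer no measurement that explains any of these steps. As far as these compounds go, whether a tert-butyl or cyclopentyl group on the same oxygen would lower the number further remains open, as does whether the carboxylic acid would keep its edge with propoxy or chloro in place of isopropoxy.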